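Swapping bromo for phenyl on a pyrimidine thioether

The source may hold more compounds than are shown below. What is called first, only, known or untested is meant among the compounds shown, and "the series" means these compounds.

Of the compounds shown here, three sharing one core have been tested in a functional assay on PC-3 cells (Homo sapiens) for inhibition, read by sulforhodamine B assay, with a stated time of 48 h, tested at 10 uM; a lower number here means less inhibition of growth, a higher number more inhibition of growth at the concentration tested. Compound 1 `CC(=O)c1ccc(Nc2ccnc(SCC(=O)c3ccc(Br)cc3)n2)cc1` gives 25%. Compound 2 `CCOC(=O)c1ccc(Nc2ccnc(SCC(=O)c3ccc([N+](=O)[O-])cc3)n2)cc1` gives 33%, a number within the usual scatter of that of compound 1, so the two cannot be told apart. Compound 3 `O=C(O)c1ccc(Nc2ccnc(SCC(=O)c3ccc(C(F)(F)F)cc3)n2)cc1` gives 12%, which lies below compound 1 by more than the scatter. Compound 1 thus sits among the two closely matched higher numbers, with compound 3 clearly beneath it.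

Compound 4 `CC(=O)c1ccc(Nc2ccnc(SCC(=O)c3ccc(-c4ccccc4)cc3)n2)cc1` is not yet measured. It differs from compound 1 in one place: phenyl in place of bromo on an aromatic carbon. Within the data shown here, since no pair of measured compounds differs in only one place, the size of such a step is unknown here, and the three measured compounds differ from one another at more than one site, which leaves no guide to the effect of this change alone. A modest shift in either direction is as plausible as none beyond the scatter.

The expected value for compound 4 in this assay is 28%, within a range from 8% to 50%. This estimate means a step from compound 1 to compound 4 of a number 3 percentage points higher from compound 1 to compound 4 (within the scatter), expected to stay within the scatter.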

Compound 4, percent growth inhibition at one concentration: 19%
Estimate against measurement, compound 4: 9 percentage points above; measured number inside the range.
By their numbers in this assay, from the lowest: compounds 3, 4, 1 and 2 (each within the scatter of the next, the first and the last beyond it).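

Among these compounds, this is the first comparison in the set that changes a single place. In this assay, putting phenyl in place of bromo on this aromatic carbon gives a number 6 percentage points lower from compound 1 to compound 4 (within the scatter). The group here can therefore grow from 1 heavy atom to 6 heavy atoms, and gain a six-membered aromatic ring, without a shift that can be told apart from the scatter. No measurement at hand bears on why the number stays within the scatter.

As far as these compounds go, the effect of an amine or a carboxylic acid on this same aromatic carbon remains open, as does that of a longer chain. A single step also cannot show whether this result holds with the other groups found on the shared core.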